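This account rests on a few compounds, and the source may have more. Where it says the series, first, only, none or still open, it means among the compounds named here.

Of the compounds shown here, three have been measured in a functional assay on FTC-133 cells (Homo sapiens) for cytotoxicity, read by MTT assay, with a stated time of 24 h (on this read-out higher numbers stand for weaker inhibition and lower numbers for stronger inhibition), so far.

- compound 1 `COc1ccc(-c2cn([C@H]3C[C@H](CO)N(C)O3)nn2)cc1` gives 7000 nM
- compound 2 `CN1O[C@H](n2cc(-c3ccccc3)nn2)C[C@@H]1CO` gives 6330 nM
- compound 3 `COc1ccc(-c2cn([C@@H]3C[C@H](CO)N(C)O3)nn2)cc1` gives 6480 nM

Compound 3, at 6480 nM, cannot be told apart from the other two, since all three values lie within the scatter of one another. The next compound, compound 4 `CN1O[C@H](n2cc(-c3ccc(F)cc3)nn2)C[C@@H]1CO`, carries fluoro in place of methoxy on an aromatic carbon, para to a large group: fluoro in place of methoxy on an aromatic carbon. For the measured compounds named here, no measured compound here carries fluoro, so the evidence is indirect. The nearest guide is methoxy in place of hydrogen at this kind of carbon, which gave a 1.0-fold higher number from compound 2 to compound 3 (0.01 log units; within the scatter). The other step, a 1.1-fold lower number from compound 1 to compound 3 (0.03 log units; within the scatter), is a change of configuration only, as the fact that compounds 1 and 3 differ only in the configuration as drawn shows, so it bears on this swap only loosely. Neither step leaves the scatter, so no real shift is expected in this assay. The expected change is a 1.1-fold lower number from compound 3 to compound 4 (0.03 log units; within the scatter). For compound 4 the estimated value is 6000 nM, with an expected range from 3200 nM to 11000 nM.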

Compound 4, half-maximal inhibitory concentration: 5850 nM
The estimate for compound 4 lay 1.0-fold (0.01 log units) above the measured number; low and high end bracket the measured number.
By their numbers in this assay, from the lowest: compounds 4, 2, 3 and 1 (each within the scatter of the next).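

In this assay, the position on the aromatic ring para to a large group has now carried hydrogen, methoxy and fluoro, and the three cannot be told apart. Fluoro in place of methoxy gives a 1.1-fold lower number from compound 3 to compound 4 (0.04 log units; within the scatter) and fluoro in place of hydrogen gives a 1.1-fold lower number from compound 2 to compound 4 (0.03 log units; within the scatter) so this is the first direct reading for a halogen here, and it shows no real shift against either neighbour. Nothing at hand speaks to the reason for this flat result.

Still open, going by these compounds, is whether any group at this position can move the number beyond the scatter, such as an amine, a carboxylic acid or a longer chain. Also open, on these data alone, is whether the fluoro compound would match its partner with the other configuration at the saturated ring carbon, as the methoxy pair does.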